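This account rests on a few compounds, and the source may have more. Where it says the series, first, only, none or still open, it means among the compounds named here.

Series notes, cytotoxicity set.

Compound 1 `COc1ccc2nc(-c3ccc(-n4c(C)ccc4-c4ccc(C)cc4)cc3)sc2c1` is the parent of the pair on the first core. In an ADME assay on MCF-10A cells (Homo sapiens) for cytotoxicity, read by MTT assay, with a stated time of 72 h (a higher number here means a weaker inhibitor, a lower number a stronger inhibitor), compound 1 gives 34000 nM. Compound 2 `COc1ccc2nc(-c3ccc(-n4c(C)ccc4-c4ccc(F)cc4)cc3)sc2c1` carries the change fluoro in place of methyl on an aromatic carbon and in this assay compound 2 gives 38300 nM; the step is a 1.1-fold higher number from compound 1 to compound 2 (0.05 log units; within the scatter).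

Compound 3 `COc1cc2nc(-c3ccc(-n4c(C)ccc4-c4ccc(C)cc4)cc3)sc2c(OC)c1OC` is the parent on the second core; in this assay compound 3 gives 42500 nM. The difference between the two cores is not broken down here. Compound 3 stands within the scatter of both compound 1 and compound 2.

Compound 4 `COc1cc2nc(-c3ccc(-n4c(C)ccc4-c4ccc(F)cc4)cc3)sc2c(OC)c1OC` is not yet measured. It differs from compound 3 by fluoro in place of methyl on an aromatic carbon, the same change as that from compound 1 to compound 2, made on the second core. The step from compound 3 to compound 4 in this assay is expected to be a 1.1-fold higher number from compound 3 to compound 4 (0.03 log units; within the scatter), resting on compound 1 and compound 2, where the same change gave a 1.1-fold higher number from compound 1 to compound 2 (0.05 log units; within the scatter) and stayed within the scatter. For compound 4 in this assay the estimate is 46000 nM, with a range from 26000 nM to 82000 nM.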

Compound 4, half-maximal inhibitory concentration: 43200 nM
Beside the measured number, compound 4's estimate is 1.1-fold (0.03 log units) above it; low and high end bracket the measured number.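

In this assay, fluoro in place of methyl on the second core, read as 4-methylphenyl to 4-fluorophenyl, gives a 1.0-fold higher number from compound 3 to compound 4 (0.01 log units; within the scatter). Set beside the same change on the first core, the new step does not differ from the earlier one: the same change on two cores in this assay, a 1.1-fold higher number (0.05 log units; within the scatter) from compound 1 to compound 2 and a 1.0-fold higher number (0.01 log units; within the scatter) from compound 3 to compound 4, 1.1-fold (0.04 log units) apart, within the scatter of two such steps

Among the compounds shown here, on these two cores, then, the change carries over in the sense that it stays within the scatter both times, but with so small a step on each core, this shows only that both readings are compatible with no detectable change; it gives no size of effect to transfer, and it says nothing about any other core or any other assay.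

Still open, going by these compounds, is whether an amine, a carboxylic acid or a longer chain such as n-butyl, set in place of the fluoro on that aromatic ring, would move the number beyond the scatter. Also open, on these data alone, is how the two cores themselves compare, since the compounds on them differ in more than one place.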